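Replacing the 1,3-Dicarboxypropyl Group of Compound 1

A few compounds are considered here, and "the series" means these few. Any claim that something is new, unique, unknown or untested is made for them only; others in the source may bear on it.

Compound 1 `Nc1nc2[nH]c(CCSCCC(=O)N[C@@H](CCC(=O)O)C(=O)O)cc2c(=O)[nH]1` has been tested in a functional assay on SW-620 cells (Homo sapiens) for antiproliferative activity, read by MTT assay, with a stated time of 72 h, in the presence of a further agent that is not named here (a higher number here means a weaker inhibitor, a lower number a stronger inhibitor), and there compound 1 gives 387 nM. Compound 2 `Nc1nc2[nH]c(CCSCC(=O)N[C@@H](CCC(=O)O)C(=O)O)cc2c(=O)[nH]1`, which carries the same 1,3-dicarboxypropyl on its amide-type nitrogen, gives 442 nM, and these two numbers lie within the usual scatter of each other. Compound 3 `Nc1nc2[nH]c(CCSCC(=O)NCc3cccnc3)cc2c(=O)[nH]1` gives 25300 nM, so compound 1 shares the low end of the three numbers with compound 2, well clear of compound 3.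

The unmeasured compound 4 `Nc1nc2[nH]c(CCSCCC(=O)NCc3cccnc3)cc2c(=O)[nH]1` differs from compound 1 in one place: (pyridin-3-yl)methyl in place of 1,3-dicarboxypropyl on an amide-type nitrogen. In words, (pyridin-3-yl)methyl stands in place of 1,3-dicarboxypropyl on an amide-type nitrogen. Among the compounds with values here, the only measured step of this kind is a 57-fold higher number from compound 2 to compound 3 (1.76 log units; beyond the scatter), a large change beyond the scatter, towards a weaker inhibitor. That is a single step, taken on compound 2 rather than on compound 1, so its size may not carry over exactly. Even so, a step of similar size and the same direction is expected in this assay, and the estimate is a 57-fold higher number from compound 1 to compound 4 (1.75 log units; beyond the scatter). For compound 4 the expected value is 22000 nM, with an estimated range from 7000 nM to 70000 nM.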

Compound 4, half-maximal inhibitory concentration: 665 nM
Compound 4: middle estimate off by 33-fold (1.52 log units), on the high side, outside the stated range (below it).
By their numbers in this assay, from the lowest: compounds 1, 2 and 4 (each within the scatter of the next); then compound 3.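

In this assay, the change on the core of compound 1 gives a 1.7-fold higher number from compound 1 to compound 4 (0.24 log units; within the scatter), so on this core the 1,3-dicarboxypropyl group is not needed for a low number, and a (pyridin-3-yl)methyl group on the amide-type nitrogen serves about as well. The large loss seen earlier therefore cannot be treated as a general penalty for removing 1,3-dicarboxypropyl from this nitrogen. What this change does depends on the rest of the molecule, as the two steps now available show: the same change on two cores in this assay, a 57-fold higher number (1.76 log units; beyond the scatter) from compound 2 to compound 3 and a 1.7-fold higher number (0.24 log units; within the scatter) from compound 1 to compound 4, 33-fold (1.52 log units) apart, beyond the scatter of two such steps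

Which feature of compound 1 and compound 2 makes the same change so much milder on one core than on the other remains open, since two steps can show that a difference exists but not where it comes from. It is also unknown whether the core of compound 1 would tolerate other groups on this nitrogen equally well, such as a plain benzyl group with no ring nitrogen, or a short chain ending in a single carboxylic acid.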